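A few compounds are considered here, and "the series" means these few. Any claim that something is new, unique, unknown or untested is made for them only; others in the source may bear on it.

Measured so far:
compound 1 `O=C(CO[N+](=O)[O-])NNC(=O)c1ccc(-n2[nH]c(=O)cc2-c2ccccc2)cc1`: 20.5%
compound 2 `CCOC(=O)c1c(-c2ccccc2O)n(-c2ccc(C(=O)NNC(=O)CO[N+](=O)[O-])cc2)[nH]c1=O`: 21.1%

In a functional assay on the whole organism (strain Wistar) for inhibition, with Rattus norvegicus as the target, read by paw edema, with stated times of 3 h and 1 h, at a dose of 6 mg/kg by the oral route (on this read-out higher numbers stand for more inhibition at the one dose given (going by the name of the read-out) and lower numbers for less inhibition), compound 2 gives 21.1%. Among the measured compounds shown here, only one other compound has been measured: compound 1 gives 20.5%, and the gap between the two lies within the scatter of repeated measurements, so the two cannot be told apart on this read-out; both sit at a modest level of inhibition.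

Compound 3 `CCOC(=O)c1c(-c2ccccc2)n(-c2ccc(C(=O)NNC(=O)CO[N+](=O)[O-])cc2)[nH]c1=O` has not been measured. Its difference from compound 2 is hydrogen in place of hydroxy on an aromatic carbon. For the measured compounds named here, no pair of measured compounds shows this change, so there is no measured step to lean on. The two numbers in hand give no sign that this series moves far on such a change, and the estimate for the step is a number 2.1 percentage points lower from compound 2 to compound 3 (within the scatter), which is not beyond the scatter, with no direction claimed. Compound 3 is therefore expected to give 19%, within a range of 8% to 30%.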

Compound 3, a percentage reported as inhibition, in the whole organism at one dose (the size of the read-out at that dose, not a potency): 59.6%
Estimate against measurement, compound 3: 40.6 percentage points below; measured number above the stated range.
By their numbers in this assay, from the lowest: compounds 1 and 2 (each within the scatter of the next); then compound 3.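

In this assay the change from 2-hydroxyphenyl to phenyl gives a number 38.5 percentage points higher from compound 2 to compound 3 (beyond the scatter) and so marks this aromatic carbon, ortho to a large group, as a place where the read-out responds strongly, which compounds 1 and 2 alone could not show. With phenyl kept, ethoxycarbonyl in place of hydrogen on an aromatic carbon gives a number 39.1 percentage points higher from compound 1 to compound 3 (beyond the scatter) and so, among these three compounds, the high number appears only where ethoxycarbonyl is present and hydroxy is absent. Nothing on hand gives a reason for either step.

The compounds shown leave open whether a methoxy or an amino group in place of the hydroxy would keep the higher number. They also leave open whether a carboxylic acid in place of ethoxycarbonyl would do so.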